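The compounds below may be only part of what the source reports. "The series", "measured", "known", "first", "only" and "open" are said of these compounds alone.

Working notes on the series. In a functional assay on HepG2 cells (Homo sapiens) for antiproliferative activity, read by XTT assay, with a stated time of 72 h (a higher number here means a weaker inhibitor, a lower number a stronger inhibitor), compound 1 `CNc1ncnc2c1c(-c1ccsc1)cn2[C@@H]1O[C@H](CO)[C@@H](O)[C@H]1O` reaches only a limit, > 20000 nM. Compound 2 `O=c1[nH]cnc2c1c(-c1ccsc1)cn2[C@@H]1O[C@H](CO)[C@@H](O)[C@H]1O` likewise gives only a limit in this assay, > 15000 nM. Compound 3 `Nc1nc2c(c(-c3ccsc3)cn2[C@@H]2O[C@H](CO)[C@@H](O)[C@H]2O)c(=O)[nH]1` also stops at a limit in this assay, > 20000 nM. The step that the two limits leave unreadable from compound 2 to compound 3 is therefore unreadable. Compound 2 thus stands at a limit, as do the two further values shown: the limit of > 15000 nM in this assay, at which 1 of the 3 values shown sits, and (the limit of > 20000 nM in this assay, at which 2 of the 3 values shown sit). Compound 4 `O=c1[nH]cnc2c1c(-c1ccccc1)cn2[C@@H]1O[C@H](CO)[C@@H](O)[C@H]1O` differs from compound 2 by phenyl in place of thiophen-3-yl on an aromatic carbon. Within the data shown here, no measured step bears on this change, and every value shown is a limit, so no direction beyond the scatter can be expected in this assay. Compound 4 is estimated at 25000 nM, with a range from 8000 nM to 80000 nM. The expected step that the limit leaves unreadable from compound 2 to compound 4 is thus none beyond the scatter, most likely ending again at a limit.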

Compound 4, half-maximal inhibitory concentration: > 20000 nM
Compound 4 ended at the assay's limit; the forecaster's own chance of this, stated with the estimate: 80%; the middle value lies beyond the limit too.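

In this assay compound 4 gives > 20000 nM, a limit. Among these compounds, compound 2 gives > 15000 nM, also a limit, so no step between them can be read. The compounds shown leave open whether phenyl and thiophen-3-yl differ at all in this assay.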